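The source may report more compounds than this note shows. Statements on the series, on what has been measured and on what is new or still open speak of the compounds shown alone.

In a functional assay on microsomes from liver (Rattus norvegicus, strain Wistar) for inhibition, with a stated time of 15 min (a lower number here means a stronger inhibitor, a higher number a weaker inhibitor), compound 3 (`COc1cc(C2CC(c3cc4ccccc4o3)=NN2C(=O)Nc2ccc(F)cc2)ccc1O`) gives 125000000 nM. Compound 2 (`COc1cc(C2CC(c3cc4ccccc4o3)=NN2C(=O)Nc2ccccc2)ccc1O`) gives 116000000 nM, and the gap, a 1.1-fold higher number from compound 2 to compound 3 (0.03 log units; within the scatter), leaves the two level. Compound 1 (`COc1cc(C2CC(c3cc4ccccc4o3)=NN2C(=O)Nc2cccc(O)c2)ccc1O`) gives 24000000 nM, the lowest number of the three, as shown by a 4.8-fold higher number from compound 1 to compound 2 (0.68 log units; beyond the scatter) and by a 5.2-fold higher number from compound 1 to compound 3 (0.72 log units; beyond the scatter).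

Compound 4 (`COc1cc(C2CC(c3cc4ccccc4o3)=NN2C(=O)Nc2ccccc2O)ccc1O`) has 2-hydroxyphenyl in place of the 4-fluorophenyl of compound 3 on an amide-type nitrogen: 2-hydroxyphenyl in place of 4-fluorophenyl on an amide-type nitrogen. Within the data shown here, two measured steps bear most directly on this change. Removing the hydroxy of compound 1 gave a 4.8-fold higher number from compound 1 to compound 2 (0.68 log units; beyond the scatter), and exchanging its 3-hydroxyphenyl for 4-fluorophenyl gave a 5.2-fold higher number from compound 1 to compound 3 (0.72 log units; beyond the scatter). Among the measured compounds shown here, compound 4 also carries a hydroxy, but no measured compound has 2-hydroxyphenyl, so the full gain cannot be assumed. A modest move toward a lower number is therefore expected, estimated as a 2.8-fold lower number from compound 3 to compound 4 (0.44 log units; beyond the scatter). Compound 4 is expected to give 45000000 nM, with an estimated range from 18000000 nM to 125000000 nM.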

Compound 4, half-maximal inhibitory concentration: 22000000 nM
The estimate for compound 4 lay 2.0-fold (0.31 log units) above the measured number; measured number inside the range.
By their numbers in this assay, from the lowest: compounds 4 and 1 (each within the scatter of the next); then compounds 2 and 3 (each within the scatter of the next).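

In this assay the 2-hydroxyphenyl group on the amide-type nitrogen gives a 5.7-fold lower number from compound 3 to compound 4 (0.75 log units; beyond the scatter) and, read as the addition of a hydroxy to the phenyl group, a 5.3-fold lower number from compound 2 to compound 4 (0.72 log units; beyond the scatter), so the drop that compound 1 had shown for 3-hydroxyphenyl is not confined to that one group. The two hydroxyphenyl groups are level, with a 1.1-fold lower number from compound 1 to compound 4 (0.04 log units; within the scatter), so these compounds give no reason to prefer one over the other, and both stand apart from phenyl and 4-fluorophenyl. Nothing measured here explains why the hydroxy-bearing groups differ from the other two.

As far as these compounds go, whether a methoxy, an amine or a carboxylic acid in place of the hydroxy would keep the lower number remains open. From the compounds shown here alone, it is also open whether a second hydroxy on the same ring would lower it further.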